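Nitrobenzimidazole thioethers: amide in place of chlorophenyl ketone

The source may report more compounds than this note shows. Statements on the series, on what has been measured and on what is new or still open speak of the compounds shown alone.

Measured so far in a functional assay on HepG2 cells (Homo sapiens) for cytotoxicity, read by MTT assay, with a stated time of 48 h; on this read-out lower numbers stand for stronger inhibition and higher numbers for weaker inhibition:
compound 1 `O=C(CSCc1nc2cc([N+](=O)[O-])ccc2[nH]1)c1ccc(Cl)cc1` — 2650 nM
compound 2 `CCOC(=O)c1c(NC(=O)CSCc2nc3cc([N+](=O)[O-])ccc3[nH]2)sc2c1CCCCC2` — 7390 nM

Compound 1 gives the lower of the two numbers; compound 2 sits higher, and the gap between them lies beyond the usual scatter. Compound 3 `NC(=O)CSCc1nc2cc([N+](=O)[O-])ccc2[nH]1` keeps the shared core and differs from compound 1 by amino in place of 4-chlorophenyl on a carbonyl carbon. No comparable change has been measured within the series, so the expectation rests on the two values alone. The step from compound 1 to compound 3 is expected to run toward a higher number, a 3.0-fold higher number from compound 1 to compound 3 (0.48 log units; beyond the scatter), beyond the scatter. Compound 3 is estimated at 8000 nM, within a range of 3000 nM to 25000 nM.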

Compound 3, half-maximal inhibitory concentration: 26900 nM
Estimate against measurement, compound 3: 3.4-fold (0.53 log units) below, and the stated range ends below it.
By their numbers in this assay, from the lowest: compound 1; then compound 2; then compound 3.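

Replacing 4-chlorophenyl with amino on a carbonyl carbon gives, in this assay, a 10-fold higher number from compound 1 to compound 3 (1.01 log units; beyond the scatter). Among these compounds, this is the first single-place step, and it shows that the group at this position strongly affects the read-out. No available measurement explains the step.

From the compounds shown here alone, it remains open whether the step follows the loss of the chlorine or of the whole aromatic ring. An unsubstituted phenyl or a methyl group on the same carbonyl carbon would separate these two readings.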